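The source may hold more compounds than are shown below. What is called first, only, known or untested is meant among the compounds shown, and "the series" means these compounds.

Measured so far in a functional assay on HT-1080 cells (Homo sapiens) for antiproliferative activity, read by sulforhodamine B assay, with a stated time of 48 h; a lower number here means a stronger inhibitor, a higher number a weaker inhibitor:
compound 1 `CC(=O)Nc1cccc(S(=O)(=O)Oc2ccccc2C(C)C)c1` gives 21000 nM;
compound 2 `CCC(=O)Nc1cccc(S(=O)(=O)Oc2ccccc2C(C)C)c1` gives 12000 nM;
compound 3 `CC(C)C(=O)Nc1cccc(S(=O)(=O)Oc2ccccc2C(C)C)c1` gives 16000 nM.

Compound 2 carries the lowest of these three numbers, yet the steps of a 1.8-fold lower number from compound 1 to compound 2 (0.24 log units; within the scatter) and a 1.3-fold higher number from compound 2 to compound 3 (0.12 log units; within the scatter) both lie within the scatter, so no real difference among the three compounds is established. All three share one core and differ only in the group on the carbonyl carbon of the amide.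

Compound 4 `CC(C)c1ccccc1OS(=O)(=O)c1cccc(NC(=O)C(C)(C)C)c1` differs from compound 2 in the same way: tert-butyl in place of ethyl on a carbonyl carbon. Among the compounds with values here, the steps that bear on this change are the three above, each of which swaps one small group for another at this carbonyl carbon, and none of them moved the number beyond the scatter, including a 1.3-fold lower number from compound 1 to compound 3 (0.12 log units; within the scatter). On that basis, the change to tert-butyl is expected to give no step beyond the scatter in this assay, in either direction. Compound 4 is therefore estimated at 15000 nM, with a range from 6000 nM to 40000 nM. This estimate means a step of a 1.3-fold higher number from compound 2 to compound 4 (0.10 log units; within the scatter), expected to stay within the scatter.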

Compound 4, half-maximal inhibitory concentration: 11000 nM
Estimate against measurement, compound 4: 1.4-fold (0.13 log units) above; low and high end bracket the measured number.
By their numbers in this assay, from the lowest: compounds 4, 2, 3 and 1 (each within the scatter of the next).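

Tert-butyl on the carbonyl carbon leaves the number in this assay within the scatter whichever group it replaces, with a 1.1-fold lower number from compound 2 to compound 4 (0.04 log units; within the scatter) when ethyl leaves and a 1.5-fold lower number from compound 3 to compound 4 (0.16 log units; within the scatter) when isopropyl leaves and a 1.9-fold lower number from compound 1 to compound 4 (0.28 log units; within the scatter) when methyl leaves. Every group shown at this place, from methyl up to tert-butyl, therefore gives the same reading within the scatter, so this carbon accepts the bulkiest of these simple carbon groups without a measurable step. Adding one methyl on the saturated chain carbon bound to the carbonyl carbon also reads alike in two settings: the same change on two cores in this assay, a 1.8-fold lower number (0.24 log units; within the scatter) from compound 1 to compound 2 and a 1.5-fold lower number (0.16 log units; within the scatter) from compound 3 to compound 4, 1.2-fold (0.08 log units) apart, within the scatter of two such steps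

From the compounds shown here alone, whether a different kind of group on this carbonyl carbon, such as an amine, a carboxylic acid or a longer chain, would move the number beyond the scatter remains open. Also open, going by these compounds, is what a methyl group in place of the amide hydrogen would do.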